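The source may report more compounds than this note shows. Statements on the series, on what has been measured and on what is new or still open speak of the compounds shown alone.

Compound 1 `Oc1ccc(-c2nc3ccccc3s2)cc1O` and compound 2 `COc1ccc(-c2nc3ccccc3s2)cc1OC` share much of their framework, but the difference between the two cores is not broken down here. In a functional assay on MDA-MB-468 cells (Homo sapiens) for antiproliferative activity (a lower number here means a stronger inhibitor of growth, a higher number a weaker inhibitor of growth), compound 1 gives 220 nM, while compound 2 gives 530 nM, the highest of the three numbers and beyond the usual scatter from both others. Compound 3 `Oc1ccc(-c2nc3cc(F)ccc3s2)cc1O` carries one change on the core of compound 1, namely (fluoro in place of hydrogen on an aromatic carbon); in this assay compound 3 gives 190 nM, a step of a 1.2-fold lower number from compound 1 to compound 3 (0.06 log units; within the scatter). Compound 4 `COc1ccc(-c2nc3ccc(F)cc3s2)cc1OC` is not yet measured; it arises from compound 2 by fluoro in place of hydrogen on an aromatic carbon, the same change at the same place. Because the earlier step of a 1.2-fold lower number from compound 1 to compound 3 (0.06 log units; within the scatter) lay within the scatter, the expected step is a 1.1-fold lower number from compound 2 to compound 4 (0.05 log units; within the scatter). Compound 4 is therefore estimated at 470 nM, between 230 nM and 950 nM.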

Compound 4, concentration for 50% growth inhibition: 5 nM
Compound 4: middle estimate off by 94-fold (1.97 log units), on the high side; the measured number lies below the stated range.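

The fluoro change gives a 110-fold lower number from compound 2 to compound 4 (2.03 log units; beyond the scatter) in this assay, so its step on one core did not carry over to the other: the same change on two cores in this assay, a 1.2-fold lower number (0.06 log units; within the scatter) from compound 1 to compound 3 and a 110-fold lower number (2.03 log units; beyond the scatter) from compound 2 to compound 4, 92-fold (1.96 log units) apart, beyond the scatter of two such steps. The size of this step therefore depends on the core within this pair of cores, and a small step on one core gave no safe guide to the step on the other. Two steps cannot show which difference between the cores matters, or whether other cores in the series would follow either one.

The compounds shown leave open whether a chloro or a nitrile in place of the fluoro would give a similarly large step on the core of compound 2. They also leave open how much the exact ring carbon carrying the fluoro contributes to the gap between the two steps.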